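This account rests on a few compounds, and the source may have more. Where it says the series, first, only, none or still open, it means among the compounds named here.

Compound 1 `COc1ccccc1C(=O)NCCNc1cccc(NS(=O)(=O)c2cc(-c3ccccc3)ccc2OC)c1`: > 10000 nM
Compound 2 `COC(=O)c1cccc(-c2ccc(OC)c(S(=O)(=O)Nc3cccc(NCCNC(=O)c4ccccc4OC)c3)c2)c1`: > 10000 nM
Compound 3 `CNC(=O)c1cccc(-c2ccc(OC)c(S(=O)(=O)Nc3cccc(NCCNC(=O)c4ccccc4OC)c3)c2)c1`: 182 nM

In an assay on CHO-K1 cells for agonist activity at Orexin receptor type 2 (Homo sapiens), read by a luciferase reporter (on this read-out higher numbers stand for an effect only at larger amounts of compound and lower numbers for an effect already at smaller amounts), compound 2 gives > 10000 nM, which is a limit of the assay and not a number. Compound 1 likewise gives > 10000 nM, also a limit. Compound 3 gives 182 nM. The step of an at least 54-fold lower number from compound 2 to compound 3 (1.73 log units; beyond the scatter) is large, while a step that the two limits leave unreadable from compound 1 to compound 2 cannot be sized, and two of the three values sit at the limit of > 10000 nM in this assay, at which 2 of the 3 values shown sit.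

Compound 4 `COc1ccccc1C(=O)NCCNc1cccc(NS(=O)(=O)c2cc(-c3cccc(N)c3)ccc2OC)c1` carries amino in place of methoxycarbonyl on an aromatic carbon. Among the measured compounds shown here, no measured step shows this exact exchange; the only large step known, an at least 54-fold lower number from compound 2 to compound 3 (1.73 log units; beyond the scatter), trades one group on the same ring position for another and lowers the number far. Because the starting point > 10000 nM is a limit, the step of an at least 5.0-fold lower number from compound 2 to compound 4 (0.69 log units; beyond the scatter) is expected only loosely. Compound 4 is estimated at 2000 nM, between 200 nM and 10000 nM.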

Compound 4, half-maximal effective concentration: > 1000 nM
Compound 4: no number, only a limit (the forecaster's own chance of this, stated with the estimate: 45%); the middle value lies beyond the limit too.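

Compound 4 gives > 1000 nM in this assay, which is a limit of the assay and not a number: the limit of > 1000 nM in this assay, at which 1 of the 4 values shown sits.

Amino in place of methylcarbamoyl still gives an at least 5.4-fold higher number from compound 3 to compound 4 (0.73 log units; beyond the scatter), so at this place a small nitrogen group does not keep the low number seen with methylcarbamoyl. The steps joining compound 4 to compound 1 and compound 2 link two limits and cannot be read.

Open, as far as these compounds go, is whether the amide hydrogen or the methyl of methylcarbamoyl counts here. A primary carboxamide, a dimethylcarbamoyl group or a carboxylic acid in this place would bear on that.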